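Aryl swap on the saturated ring carbon of compound 1

The source may hold more compounds than are shown below. What is called first, only, known or untested is meant among the compounds shown, and "the series" means these compounds.

Measured so far:
- compound 1, `COc1cc(C2=NN(C(C)=O)C(c3cc(Cl)cc(Cl)c3)O2)cc(OC)c1OC`: 6.6% in a functional assay on BGC-823 cells (Homo sapiens) for antiproliferative activity, read by MTT assay, tested at 5 uM; on this read-out lower numbers stand for a weaker effect and higher numbers for a stronger effect at the one concentration tested
- compound 2, `COc1cc(C(=O)N/N=C/c2c(Cl)cccc2Cl)cc(OC)c1OC`: 27.8% in this assay

Compound 1 stands lowest of the two numbers in this assay; its nearest neighbour, compound 2, lies higher by a margin beyond the usual scatter. Within the data shown here, no step between two measured compounds differing in a single place is available, so nothing shows how a change on the saturated ring carbon moves the read-out in this assay.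

Compound 3, `COc1cc(C2=NN(C(C)=O)C(c3ccc(C(F)(F)F)cc3)O2)cc(OC)c1OC`, is not yet measured. It differs from compound 1 in one place: 4-(trifluoromethyl)phenyl in place of 3,5-dichlorophenyl on a saturated ring carbon. Compound 2 shares neither the shared core of compound 1 nor this substituent pattern, so its value offers no guide to the swap.

In the absence of any recorded step, the step of a number 3.4 percentage points higher from compound 1 to compound 3 (within the scatter) is expected to be small and within the scatter, in no firm direction. Compound 3 is estimated at 10% in this assay. For compound 3 the expected range runs from 0% to 25%.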

Compound 3, a percentage reported as inhibition, at one concentration (the size of the read-out at that concentration, not a potency): 3.4%
Estimate against measurement, compound 3: 6.6 percentage points above; the range from low to high includes it.
By their numbers in this assay, from the lowest: compounds 3 and 1 (each within the scatter of the next); then compound 2.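

Among these compounds, on the saturated ring carbon, 4-(trifluoromethyl)phenyl in place of 3,5-dichlorophenyl provides the first readable step at this position in this assay: a number 3.2 percentage points lower from compound 1 to compound 3 (within the scatter). These two substituted phenyl groups therefore cannot be told apart on this read-out at the one concentration tested, even though both the substituents and their placement on the ring differ. No measurement bears on why the swap leaves the read-out within the scatter.

Only these two substituted phenyl groups are shown on this carbon, so it remains open whether any group here can move the read-out beyond the scatter. A phenyl ring bearing an amine or a carboxylic acid would test this, as would a longer alkyl chain in place of the ring.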